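Cytotoxicity limits across a substituted benzylamine series

The compounds below may be only part of what the source reports. "The series", "measured", "known", "first", "only" and "open" are said of these compounds alone.

compound 1 `CCC(CC)Oc1cccc(CN[C@H]2CC(C(=O)O)=C[C@@H](OC(CC)CC)[C@@H]2NC(C)=O)c1`: > 200000 nM
compound 2 `CCC(CC)O[C@@H]1C=C(C(=O)O)C[C@H](NCc2ccc(SC3CCCC3)cc2)[C@H]1NC(C)=O`: > 200000 nM

In an ADME assay on cells (Fibroblast, Gallus gallus) for cytotoxicity, read by CCK-8 assay, with a stated time of 48 h (a lower number here means that less compound is tolerated, a higher number that more compound is tolerated), compound 1 returns > 200000 nM, a limit of the assay rather than a number. Compound 2 likewise returns > 200000 nM, again only a limit. Compound 2 therefore stands at the limit of > 200000 nM in this assay, at which 2 of the 2 values shown sit. Compound 3 `CCC(CC)O[C@@H]1C=C(C(=O)O)C[C@H](NCc2ccc(S(=O)(=O)c3ccccc3)cc2)[C@H]1NC(C)=O` carries phenylsulfonyl in place of cyclopentylsulfanyl on an aromatic carbon. Among the compounds with values here, no measured step between compounds covers this change, so no size can be read from the data. The expected step of a number no higher from compound 2 to compound 3 (the limit leaves the size open) is none beyond the scatter. Compound 3 is estimated at 200000 nM, in the range 100000 nM to 400000 nM, most probably again reported only as a limit.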

Compound 3, half-maximal cytotoxic concentration: > 200000 nM
Compound 3: no number, only a limit; the forecaster's own chance of this, stated with the estimate: 80%; the middle value lies on the limit itself.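

Within the data shown here, compound 2 and compound 3 are both reported only as limits in this assay, so no step between them can be read. Where the true cytotoxic concentration of either compound lies, and whether phenylsulfonyl in place of cyclopentylsulfanyl shifts it, stays open.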